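The compounds below may be only part of what the source reports. "The series", "measured", "known", "first", "only" and "open" are said of these compounds alone.

In a functional assay on the whole organism (strain Swiss) with Mus musculus as the target, in the maximal electroshock model, with a stated time of 0.5 h, at a dose of 300 mg/kg by the intraperitoneal route (on this read-out higher numbers stand for a stronger effect at the one dose given and lower numbers for a weaker effect), compound 1 `COc1cccc(N2CCN(C(=O)C(C)N3C(=O)CCC3=O)CC2)c1` gives 50%, the highest of the three numbers recorded. Compound 2 `CCC(C(=O)N1CCOCC1)N1C(=O)CCC1=O` gives 0%, and compound 3 `CCC(C(=O)N1CCN(c2cccc(OC)c2)CC1)N1C(=O)CCC1=O` gives 0%, so these two sit alike at the bottom. Among the measured compounds shown here, the only step measured in a single place, a number 50 percentage points lower from compound 1 to compound 3 (beyond the scatter), concerns the saturated chain and not the aromatic ring, so no measured step bears directly on the change from compound 1 to compound 4 `CC(C(=O)N1CCN(c2cccc(F)c2)CC1)N1C(=O)CCC1=O`, which is fluoro in place of methoxy on an aromatic carbon. With the ring substituent otherwise unexplored, a moderate fall is expected rather than a complete loss of effect. Compound 4 is therefore estimated at 40%, within 0% to 80%. The expected step is a number 10 percentage points lower from compound 1 to compound 4 (within the scatter).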

Compound 4, a percentage reported as activity, at one dose (the size of the read-out at that dose, not a potency): 50%
Compound 4: the middle estimate sits 10 percentage points below what was measured; low and high end bracket the measured number.
By their numbers in this assay, from the lowest: compounds 2 and 3 (each within the scatter of the next); then compounds 1 and 4 (each within the scatter of the next).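

In this assay the step of no change at the digits printed from compound 1 to compound 4 (within the scatter) shows that, on the core of compound 1, fluoro can stand in place of methoxy on this aromatic carbon with the effect at the one dose held, although one heavy atom replaces two and the hydrogen-bond acceptor of methoxy is gone. The earlier compounds shown here spoke only to the saturated chain, leaving this ring position untested. Nothing on hand gives a reason for this result. On these data alone, whether an amine or a carboxylic acid on this aromatic carbon would also hold the effect stays open, and so does whether 3-fluorophenyl would keep it with the extra methyl on the saturated chain.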